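This account rests on a few compounds, and the source may have more. Where it says the series, first, only, none or still open, it means among the compounds named here.

Compound 3 `CC(C)C(/C=C1\NC(=O)NC1=O)c1ccc(-c2ccc3cccc(F)c3c2)[nH]c1=O` is the point of departure. In an ADME assay on MDCK cells (Canis lupus familiaris) for permeability, in the apical to basolateral direction (a higher number here means that the compound crosses the layer faster, a lower number that the compound crosses the layer more slowly), compound 3 gives 12.3 10^-6 cm/s, the highest of the two numbers recorded. Compound 2 `CC(C)[C@@H](c1ccc(-c2ccc3cccc(F)c3c2)[nH]c1=O)[C@@H]1OC(=O)NC1=O` gives 3.15 10^-6 cm/s in this assay, a lower number, and the gap between the two lies beyond the scatter. For compound 1 `CC(C)C(c1ccc(-c2ccc3cccc(F)c3c2)[nH]c1=O)C1C(=O)NC(=O)N1C` the entry in this assay is "not determined" (no result reported); no number was reported for it. Compound 4 `CC(C)C(/C=C1/C(=O)NC(=O)N1C)c1ccc(-c2ccc3cccc(F)c3c2)[nH]c1=O` differs from compound 3 in one place: methyl in place of hydrogen on an amide-type nitrogen in a ring. For the measured compounds named here, no step between measured compounds is recorded for a change of this kind, so nothing in the numbers fixes its size. A modest rise is expected, amounting to a 1.5-fold higher number from compound 3 to compound 4 (0.17 log units; within the scatter), though it may remain near the scatter. Compound 4 is therefore estimated at 18 10^-6 cm/s, within a range of 9 10^-6 cm/s to 36 10^-6 cm/s.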

Compound 4, apparent permeability: 14.1 10^-6 cm/s
Estimate against measurement, compound 4: 1.3-fold (0.11 log units) above; the range from low to high includes it.
By their numbers in this assay, from the lowest: compound 2; then compounds 3 and 4 (each within the scatter of the next).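

Methyl in place of hydrogen on an amide-type nitrogen in a ring now has a measured step at this position: in this assay, it amounts to a 1.1-fold higher number from compound 3 to compound 4 (0.06 log units; within the scatter). The amide hydrogen can therefore be replaced by methyl here with the number remaining within the scatter of that of compound 3. No measurement shown here accounts for this result.

The compounds shown leave open whether ethyl, or a longer chain ending in an amine, on this nitrogen would stay within that scatter. A single step also cannot show whether methyl would behave alike on another compound.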